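This account rests on a few compounds, and the source may have more. Where it says the series, first, only, none or still open, it means among the compounds named here.

Compounds measured so far in a functional assay on LOX IMVI cells (Homo sapiens) for inhibition, read by sulforhodamine B assay, with a stated time of 48 h; a higher number here means that more compound is tolerated, a lower number that less compound is tolerated:
Compound 1 `O=C(Nc1cccc(-n2cc(-c3ccncc3)c(-c3ccc(Cl)c(O)c3)n2)c1)Nc1cccc(C(F)(F)F)c1` gives 32400 nM in this assay.
Compound 2 `COc1cc(-c2nn(-c3cccc(NC(=O)Nc4cc(C(F)(F)F)cc(C(F)(F)F)c4)c3)cc2-c2ccncc2)ccc1Cl` gives 2940 nM in this assay.
Compound 3 `COc1cc(-c2nn(-c3cccc(NC(=O)Nc4cccc(C(F)(F)F)c4)c3)cc2-c2ccncc2)ccc1Cl` gives 3460 nM in this assay.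

Compound 3 stands second highest of the three numbers in this assay. Its nearest neighbour is compound 2, from which the step of a 1.2-fold higher number from compound 2 to compound 3 (0.07 log units; within the scatter) is within the scatter, so the two cannot be ordered. The step of a 9.4-fold lower number from compound 1 to compound 3 (0.97 log units; beyond the scatter) is the only one that lies beyond the scatter; it concerns the methyl on the oxygen of the other aryl ring and does not touch the urea side.

Compound 4 `COc1cc(-c2nn(-c3cccc(NC(=O)Nc4ccc(Cl)c(C(F)(F)F)c4)c3)cc2-c2ccncc2)ccc1Cl` is not yet measured. It differs from compound 3 by chloro in place of hydrogen on an aromatic carbon. The step that bears on this change is the one on the same aryl urea ring: a 1.2-fold higher number from compound 2 to compound 3 (0.07 log units; within the scatter) shows that removing a second trifluoromethyl there leaves the number within the scatter. The step of a 9.4-fold lower number from compound 1 to compound 3 (0.97 log units; beyond the scatter) concerns a different part of the molecule and is not taken as a guide. On this evidence, adding a chloro on that ring is expected to give a step of a 1.2-fold lower number from compound 3 to compound 4 (0.06 log units; within the scatter) that stays within the scatter. Compound 4 is therefore estimated at 3000 nM in this assay, with a range from 1200 nM to 7500 nM.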

Compound 4, concentration lethal to 50% of the cells: 17900 nM
The estimate for compound 4 lay 6.0-fold (0.78 log units) below the measured number, and the stated range ends below it.
By their numbers in this assay, from the lowest: compounds 2 and 3 (each within the scatter of the next); then compounds 4 and 1 (each within the scatter of the next).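

In this assay, chloro on an aromatic carbon of the 3-(trifluoromethyl)phenyl ring, ortho to a trifluoromethyl group and para to a large group, gives a 5.2-fold higher number from compound 3 to compound 4 (0.71 log units; beyond the scatter), so this place on the ring responds to substitution and the chloro compound shows the higher number, meaning that more of it is tolerated. The earlier step on the same ring, a 1.2-fold higher number from compound 2 to compound 3 (0.07 log units; within the scatter), lies within the scatter, so a result for the trifluoromethyl change at one place on this ring does not carry over to a chloro at another; the two steps differ in both the group and the place, and neither pair separates those two factors. Nothing available here accounts for the size or direction of the chloro step.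

Whether a fluoro, methyl or methoxy at this same place would give a step of similar direction and size remains open, as only chloro is shown there. Also open, as far as these compounds go, is whether the chloro step would persist without the trifluoromethyl group ortho to it, or on the hydroxy form of the other aryl ring seen in compound 1.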